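Adding a methylamino group to the core of compound 3

The source may hold more compounds than are shown below. What is called first, only, known or untested is meant among the compounds shown, and "the series" means these compounds.

Compound 1 `Fc1ccc2nc(-c3cnco3)n(C3CC3)c2c1`: > 10000 nM in an ADME assay on cells for inhibition of cytochrome P450 11B1, mitochondrial (Homo sapiens), read by HPLC, with a stated time of 60 min; a lower number here means a stronger inhibitor, a higher number a weaker inhibitor
Compound 2 `Fc1ccc2nc(-c3cccnn3)n(C3CC3)c2c1`: > 10000 nM
Compound 3 `Fc1cc2nc(-c3cncnc3)n(C3CC3)c2cc1F`: 2270 nM

In this assay compound 1 reaches only a limit of the assay. Compound 2 likewise reaches only a limit. Within the data shown here, compound 3 gives the single number in the set, 2270 nM, and so stands alone as the one compound with a readable potency. Among the measured compounds shown here, the one measured step, a step that the two limits leave unreadable from compound 1 to compound 2, cannot be read because the limit of > 10000 nM in this assay, at which 2 of the 3 values shown sit, holds both of its ends.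

Compound 4 `CNc1ncncc1-c1nc2cc(F)c(F)cc2n1C1CC1` is built from compound 3 by methylamino in place of hydrogen on an aromatic carbon. For the measured compounds named here, no measured step touches this change: the only step available, from compound 1 to compound 2, is unreadable and concerns a different position. The expectation for compound 4 therefore rests on compound 3 alone, with a wide margin. Compound 4 is expected to show a step of a 1.3-fold lower number from compound 3 to compound 4 (0.10 log units; within the scatter) in this assay, that is, none beyond the scatter. Compound 4 is estimated at 1800 nM, within a range from 400 nM to 8000 nM.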

Compound 4, half-maximal inhibitory concentration: 390 nM
Compound 4: the middle estimate sits 4.6-fold (0.66 log units) above what was measured; the whole stated range lies above it.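

In this assay, methylamino in place of hydrogen on an aromatic carbon, next to the ring nitrogen and ortho to a large group, gives a 5.8-fold lower number from compound 3 to compound 4 (0.76 log units; beyond the scatter). Among these compounds, this is the only readable step in the set, as the earlier step between two limits cannot be read, and it gives the first sign that this position of the six-membered aromatic ring with 2 nitrogen can carry a substituent while inhibition becomes stronger. None of the measurements shown speaks to what lies behind this step.

From the compounds shown here alone, the step rests on a single pair of compounds, and it remains open whether it belongs to methylamino itself or to a substituent at this position more generally. Going by these compounds, whether an unsubstituted amine, dimethylamino or methoxy on the same carbon would move the number as far also remains open.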